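A Difluorophenyl Exchange at the Aromatic Nitrogen

The source may hold more compounds than are shown below. What is called first, only, known or untested is meant among the compounds shown, and "the series" means these compounds.

Of the compounds shown here, three sharing one core have been measured in a functional assay on HT-29 cells (Homo sapiens) for cytotoxicity, read by MTT assay, with a stated time of 72 h; on this read-out lower numbers stand for stronger inhibition and higher numbers for weaker inhibition. Compound 1 `COc1cc2c(Oc3ccc(NC(=O)c4nnn(-c5ccc(F)c(F)c5)c4C(F)(F)F)cc3F)ccnc2cc1OCCCN1CCCCC1` gives 180 nM. Compound 2 `COc1cc2c(Oc3ccc(NC(=O)c4nnn(-c5ccc(C)cc5)c4C(F)(F)F)cc3F)ccnc2cc1OCCCN1CCC(C)CC1` gives 1200 nM, and compound 3 `COc1cc2c(Oc3ccc(NC(=O)c4nnn(-c5ccccc5C(F)(F)F)c4C(F)(F)F)cc3F)ccnc2cc1OCCCN1CCC(C)CC1` gives 200 nM. On these numbers compound 3 stands second highest of the three; its nearest neighbour is compound 1, within the scatter, while compound 2 lies well above it. Going by the values given here, the one single-point step among the measured compounds is a 6.0-fold lower number from compound 2 to compound 3 (0.78 log units; beyond the scatter), a modest change that lies beyond the scatter.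

Compound 4 `COc1cc2c(Oc3ccc(NC(=O)c4nnn(-c5ccc(F)c(F)c5)c4C(F)(F)F)cc3F)ccnc2cc1OCCCN1CCC(C)CC1` is not yet measured. It differs from compound 3 in one place: 3,4-difluorophenyl in place of 2-(trifluoromethyl)phenyl on an aromatic nitrogen. Among the compounds with values here, no measured step matches this exchange directly. Compound 1 carries the same 3,4-difluorophenyl group, though it differs from compound 4 elsewhere, and its value sits within the scatter of compound 3, so these two values give no sign that the entering group moves the number far. Within the data shown here, the only sizeable measured step, which involves the 4-methylphenyl group of compound 2, does not concern the entering group. The step expected in this assay is no change at the digits printed from compound 3 to compound 4 (within the scatter), within the scatter. The estimate for compound 4 is 200 nM, with a range from 80 nM to 500 nM.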

Compound 4, half-maximal inhibitory concentration: 190 nM
Compound 4: the middle estimate sits 1.1-fold (0.02 log units) above what was measured, and the stated range covers the measured number.
By their numbers in this assay, from the lowest: compounds 1, 4 and 3 (each within the scatter of the next); then compound 2.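

In this assay the exchange of 2-(trifluoromethyl)phenyl for 3,4-difluorophenyl on the aromatic nitrogen gives a 1.1-fold lower number from compound 3 to compound 4 (0.02 log units; within the scatter) and so the two groups cannot be told apart at this position on this read-out. With the rest of the structure held constant, 3,4-difluorophenyl in place of 4-methylphenyl gives a 6.3-fold lower number from compound 2 to compound 4 (0.80 log units; beyond the scatter) which shows that, among the three groups seen here on this nitrogen, 4-methylphenyl alone stands apart, and that the earlier gap for compound 2 does not depend on the trifluoromethyl group of compound 3 alone. Going by these compounds alone, the new compound also gives the first reading at the saturated ring, where methyl in place of hydrogen gives a 1.1-fold higher number from compound 1 to compound 4 (0.02 log units; within the scatter) and so leaves the number unmoved beyond the scatter while 3,4-difluorophenyl sits on the nitrogen.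

The compounds shown leave open how an unsubstituted phenyl, a pyridine ring or a benzyl group would read on this nitrogen, and whether the methyl on the saturated ring would read the same alongside 4-methylphenyl. Nothing at hand accounts for why 4-methylphenyl stands apart from the other two groups.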